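Moving the pyridine nitrogen on the shared core of compound 2

This account rests on a few compounds, and the source may have more. Where it says the series, first, only, none or still open, it means among the compounds named here.

Compound 2 `CC(=O)N(C)c1ccc(Nc2nccc(-c3cccnc3)n2)cc1` gives 900 nM in a functional assay for inhibition, with Homo sapiens as the target; a higher number here means a weaker inhibitor, a lower number a stronger inhibitor; compound 1 `CN(C)CCCOc1ccc(Nc2nccc(-c3cccnc3)n2)cc1` gives 600 nM and compound 3 `COc1ccc(Nc2nccc(-c3cccnc3)n2)cc1` gives 1700 nM, so compound 2 sits within the scatter of both, as a 1.5-fold higher number from compound 1 to compound 2 (0.18 log units; within the scatter) and a 1.9-fold higher number from compound 2 to compound 3 (0.28 log units; within the scatter) show, while a 2.8-fold higher number from compound 1 to compound 3 (0.45 log units; beyond the scatter) is modest. Compound 4 `CC(=O)N(C)c1ccc(Nc2nccc(-c3ccncc3)n2)cc1` differs from compound 2 in one place: pyridin-4-yl in place of pyridin-3-yl on an aromatic carbon. Among the compounds with values here, none of the measured steps touches this ring; all three vary the group on the other aromatic carbon, so nothing here tells how this assay answers to the change. The expected step is therefore small, a 1.3-fold higher number from compound 2 to compound 4 (0.12 log units; within the scatter), with no direction beyond the scatter. Compound 4 is estimated at 1200 nM, between 400 nM and 4000 nM.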

Compound 4, half-maximal inhibitory concentration: 500 nM
Compound 4: the middle estimate sits 2.4-fold (0.38 log units) above what was measured; the measured number falls inside the stated range.
By their numbers in this assay, from the lowest: compounds 4, 1, 2 and 3 (each within the scatter of the next, the first and the last beyond it).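

In this assay, the first change measured on this ring, from pyridin-3-yl to pyridin-4-yl, gives a 1.8-fold lower number from compound 2 to compound 4 (0.26 log units; within the scatter). With the atoms unchanged and only their joining different, moving the ring nitrogen to the position opposite the bond to the shared core leaves the number within the scatter. No measurement shown offers an explanation for this result.

The compounds shown leave open whether phenyl, with no ring nitrogen, or pyridin-2-yl would shift the number beyond the scatter. They also leave open whether pyridin-4-yl behaves the same alongside 3-(dimethylamino)propoxy or methoxy on the other aromatic ring.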